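The source may report more compounds than this note shows. Statements on the series, on what has been measured and on what is new or still open speak of the compounds shown alone.

The series shares one core, carrying an aryl ketone on a saturated ring carbon, and varies only the aryl group of that ketone. Compound 1 `COc1cc(-c2nnc3n2NC(c2cccs2)C(C(=O)c2ccc(C)cc2)S3)cc(OC)c1OC` gives 5090 nM in a functional assay on PC-3 cells (Homo sapiens) for cytotoxicity, read by MTT assay, with a stated time of 48 h; on this read-out higher numbers stand for weaker inhibition and lower numbers for stronger inhibition. Compound 2 `COc1cc(-c2nnc3n2NC(c2cccs2)C(C(=O)c2ccccc2)S3)cc(OC)c1OC` gives 86300 nM, and compound 3 `COc1cc(-c2nnc3n2NC(c2cccs2)C(C(=O)c2ccc(F)cc2)S3)cc(OC)c1OC` gives 27400 nM. Among the three measured compounds, compound 3 stands second highest: a 5.4-fold higher number from compound 1 to compound 3 (0.73 log units; beyond the scatter), while a 3.1-fold lower number from compound 2 to compound 3 (0.50 log units; beyond the scatter). The remaining step, a 17-fold higher number from compound 1 to compound 2 (1.23 log units; beyond the scatter), is the largest of the three.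

Compound 4 `COc1cc(C(=O)C2Sc3nnc(-c4cc(OC)c(OC)c(OC)c4)n3NC2c2cccs2)cc(OC)c1OC` is the next member; it differs from compound 3 in that (3,4,5-trimethoxyphenyl in place of 4-fluorophenyl on a carbonyl carbon). Going by the values given here, no measured step swaps one aryl group for a differently substituted one of this kind; the three steps only exchange hydrogen, fluoro and methyl on the same ring. What they show is that a substituted ring has given the lower number each time, methyl lower than fluoro and fluoro lower than hydrogen. As far as these compounds go, whether three methoxy groups continue that trend is untested, so the expectation for compound 4 is weak. A modest lowering is expected, a 2.7-fold lower number from compound 3 to compound 4 (0.44 log units; beyond the scatter), with a wide range. Compound 4 is estimated at 10000 nM in this assay, between 2000 nM and 50000 nM.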

Compound 4, half-maximal inhibitory concentration: > 100000 nM
Compound 4 gave a limit, no number; the forecaster's own chance of this, stated with the estimate: 10%; at least 10-fold (1.00 log units) between middle value and limit.
By their numbers in this assay, from the lowest: compound 1; then compound 3; then compound 2. At a limit, above all of these: compound 4.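

Compound 4 gives a limit and not a number: the limit of > 100000 nM in this assay, at which 1 of the 4 values shown sits. On a carbonyl carbon, the aryl group can therefore move the read-out to the top of its range, and the swap to 3,4,5-trimethoxyphenyl is a clear loss against both substituted rings, with an at least 19-fold higher number from compound 1 to compound 4 (1.29 log units; beyond the scatter) and an at least 3.6-fold higher number from compound 3 to compound 4 (0.56 log units; beyond the scatter). Going by these compounds alone, the earlier pattern, in which a substituted ring gave the lower number, thus holds only for compound 1 and compound 3, and compound 4 goes against it: the comparison with the unsubstituted phenyl ring is an at least 1.1-fold higher number from compound 2 to compound 4 (0.06 log units; that floor lies within the scatter), which places no order on that pair but shows no gain from the three methoxy groups.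

The compounds shown leave open whether the loss follows from the number of methoxy groups or from methoxy itself, and a phenyl ring carrying a single methoxy group would separate the two. As far as these compounds go, it also remains open whether the lowering seen with 4-methylphenyl extends to a longer chain such as ethyl, or to a chloro group or an amine on the same ring.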